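This account rests on a few compounds, and the source may have more. Where it says the series, first, only, none or still open, it means among the compounds named here.

Notes on the series, step from compound 2 to compound 3.

Compound 1 `COc1ccc(-c2cc(C)cc(C(=O)Nc3nn[nH]n3)n2)cc1` gives in a functional assay on the whole organism with Rattus norvegicus as the target, at a dose of 3 mg/kg by the oral route (a lower number here means a weaker effect, a higher number a stronger effect of the compound at the dose given), a reading of 43%. Compound 2 `Cc1ccc(-c2cc(C)cc(C(=O)Nc3nn[nH]n3)n2)cc1` gives in this assay a reading of 100%. Going by the values given here, the one step measured so far, a number 57 percentage points higher from compound 1 to compound 2 (beyond the scatter), runs between these two. Among the compounds with values here, compound 2 thus stands highest of the two compounds measured, at the full-inhibition reading, with compound 1 the only neighbour.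

Compound 3 `CCCc1cc(C(=O)Nc2nn[nH]n2)nc(-c2ccc(C)cc2)c1` differs from compound 2 by ethyl in place of hydrogen on a saturated chain carbon bound to an aromatic carbon. Within the data shown here, no measured step touches this kind of change; the only known step concerns a group on the aromatic ring, not a chain carbon, so it gives no direction for the propyl chain. With compound 2 already at the top of the scale, no rise can show. The expected change is therefore a number 12 percentage points lower from compound 2 to compound 3 (beyond the scatter), none beyond the scatter or a modest fall. Compound 3 is estimated at 88%, between 55% and 100%.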

Compound 3, a percentage reported as inhibition, in the whole organism at one dose (the size of the read-out at that dose, not a potency): 50%
Estimate against measurement, compound 3: 38 percentage points above; measured number outside the range, below it.
By their numbers in this assay, from the lowest: compounds 1 and 3 (each within the scatter of the next); then compound 2.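

In this assay, the saturated chain carbon bound to an aromatic carbon proves sensitive to substitution: ethyl in place of hydrogen, which also reads as methyl to propyl, gives a number 50 percentage points lower from compound 2 to compound 3 (beyond the scatter). Going by these compounds alone, the earlier step showed only that a change on an aromatic carbon can move this read-out, whereas this one shows that lengthening the chain can do so as well, and by a large amount. Nothing measured accounts for the size of this step.

Still open, on these data alone, is whether a shorter ethyl chain or a longer butyl chain at this place would lessen or deepen the fall. The compounds shown also do not tell how a propyl chain carrying an amine or a carboxylic acid would read.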